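A few compounds are considered here, and "the series" means these few. Any claim that something is new, unique, unknown or untested is made for them only; others in the source may bear on it.

Measured compounds:
Compound 1, `O=C(O)c1ccccc1-c1ccc(CCc2ncc(CC3CCOCC3)[nH]2)cc1`, 338 nM
Compound 2, `O=C(O)c1ccccc1-c1ccc(CCc2ncc(Cc3ccccc3Cl)[nH]2)cc1`, 292 nM

Both were tested in an in vitro functional assay on cells for agonist activity at Bombesin receptor subtype-3 (Homo sapiens), read by luminescence and calcium flux; on this read-out higher numbers stand for an effect only at larger amounts of compound and lower numbers for an effect already at smaller amounts. Going by the values given here, compound 2 gives the lowest of the two numbers, though its nearest neighbour, compound 1, is within the scatter of it: the only measured step, a 1.2-fold lower number from compound 1 to compound 2 (0.06 log units; within the scatter), shows that exchanging the oxan-4-yl group for 2-chlorophenyl on a saturated chain carbon bound to an aromatic carbon left the read-out essentially unchanged.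

The next compound, compound 3, is `O=C(O)c1ccccc1-c1ccc(CCc2ncc(Cc3ccc(F)cc3)[nH]2)cc1`. Relative to compound 2 the change is 4-fluorophenyl in place of 2-chlorophenyl on a saturated chain carbon bound to an aromatic carbon.

Among the compounds with values here, no measured step covers this exact exchange. Within the data shown here, the one available step, a 1.2-fold lower number from compound 1 to compound 2 (0.06 log units; within the scatter), concerns a different pair of groups at the same saturated chain carbon and stayed within the scatter, so there is no evidence that altering the group at this position moves the number much. Compound 3 is therefore expected to land close to compound 2, with the estimated step of a 1.2-fold higher number from compound 2 to compound 3 (0.08 log units; within the scatter) lying within the scatter. The estimate for compound 3 in this assay is 350 nM, ranging from 120 nM to 1000 nM.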

Compound 3, half-maximal effective concentration: 1600 nM
The estimate for compound 3 lay 4.6-fold (0.66 log units) below the measured number, outside the stated range (above it).
By their numbers in this assay, from the lowest: compounds 2 and 1 (each within the scatter of the next); then compound 3.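

The group on this saturated chain carbon is not indifferent in this assay: 4-fluorophenyl in place of 2-chlorophenyl gives a 5.5-fold higher number from compound 2 to compound 3 (0.74 log units; beyond the scatter) and 4-fluorophenyl in place of oxan-4-yl gives a 4.7-fold higher number from compound 1 to compound 3 (0.68 log units; beyond the scatter) for the same position. The earlier step stayed within the scatter and gave no sign that this position could move the number, yet here an exchange between two groups that match in heavy-atom count, ring type, hydrogen-bond donors and acceptors, and charge produces a step beyond the scatter, so these counts alone do not account for the read-out at this position. Nothing available here speaks to why 4-fluorophenyl differs from the other two groups.

The exchange from 2-chlorophenyl to 4-fluorophenyl alters both the halogen and the place it holds on the ring, so the compounds shown cannot separate these two changes, which 4-chlorophenyl and 2-fluorophenyl on the same carbon would do. On these data alone, it also remains open how this position responds to a group of another kind, such as a piperidin-4-yl amine or a plain unsubstituted phenyl.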